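This account rests on a few compounds, and the source may have more. Where it says the series, first, only, none or still open, it means among the compounds named here.

Measured in a functional assay on K562 cells (Homo sapiens) for inhibition, read by fluorescence, with a stated time of 72 h; a lower number here means a stronger inhibitor of growth, a higher number a weaker inhibitor of growth:
Compound 1 `CC(C)c1nccc2nn(-c3ccccc3)cc12` gives > 100000 nM, which is a limit of this assay.
Compound 2 `Cc1nc(-c2ccsc2)cc2nn(-c3ccccc3)cc12` gives 10000 nM.
Compound 3 `c1ccc(-n2cc3cnccc3n2)cc1` gives > 100000 nM, again a limit.

Compound 3 therefore has no number to place it, only the limit. Since the limit of > 100000 nM in this assay, at which 2 of the 3 values shown sit, also holds compound 1, the step that the two limits leave unreadable from compound 1 to compound 3 cannot be read. Compound 4 `c1ccc(-n2cc3cnc(-c4ccsc4)cc3n2)cc1` differs from compound 3 by thiophen-3-yl in place of hydrogen on an aromatic carbon. For the measured compounds named here, no measured step bears directly on this change. Compound 2 carries the same thiophen-3-yl together with a methyl group and sits at a readable number in this assay. On that basis compound 4 is expected to move off the limit toward stronger inhibition, the expected step being an at least 4.0-fold lower number from compound 3 to compound 4 (0.60 log units; beyond the scatter). Compound 4 is estimated at 25000 nM, within 8000 nM to 100000 nM.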

Compound 4, concentration for 50% growth inhibition: 8300 nM
Beside the measured number, compound 4's estimate is 3.0-fold (0.48 log units) above it, and the stated range covers the measured number.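

In this assay, thiophen-3-yl on the aromatic carbon next to the ring nitrogen brings the series off the limit, with an at least 12-fold lower number from compound 3 to compound 4 (1.08 log units; beyond the scatter). Compound 3 holds only a limit, so this step is a bound and not a full size: the limit of > 100000 nM in this assay, at which 2 of the 4 values shown sit. With hydrogen in place of methyl on an aromatic carbon, the result is a 1.2-fold lower number from compound 2 to compound 4 (0.08 log units; within the scatter), so the readable number does not need the methyl group.

Going by these compounds, whether this position tolerates an amine or a carboxylic acid remains open. So does whether a different five-membered aromatic ring would hold the number.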